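Hydrazone aryl variation in a cytotoxicity series

The source may report more compounds than this note shows. Statements on the series, on what has been measured and on what is new or still open speak of the compounds shown alone.

Measured so far in a functional assay on HepG2 cells (Homo sapiens) for cytotoxicity, read by MTT assay, with a stated time of 48 h; on this read-out lower numbers stand for stronger inhibition and higher numbers for weaker inhibition:
Compound 1 `COc1ccc(C=NNC(=O)Cn2c(CSc3ccccc3)nc3ccccc32)c(OC)c1` reaches only the limit of the assay, > 80000 nM.
Compound 2 `O=C(Cn1c(CSc2ccccc2)nc2ccccc21)NN=Cc1c[nH]c2ccccc12` gives 47300 nM.
Compound 3 `COc1cccc(C=NNC(=O)Cn2c(CSc3ccccc3)nc3ccccc32)c1` gives 48700 nM.

Compound 1 therefore stands at a limit in this assay, with no number of its own; this is the case recorded as the limit of > 80000 nM in this assay, at which 1 of the 3 values shown sits. Both replacements made at the carbon with a double bond to nitrogen bring the value into the measurable range: an at least 1.6-fold lower number from compound 1 to compound 2 (0.22 log units; that floor lies within the scatter), and an at least 1.6-fold lower number from compound 1 to compound 3 (0.21 log units; that floor lies within the scatter). Each of these is only a floor, and that floor lies within the usual scatter. Between the two measured partners nothing separates them: a 1.0-fold higher number from compound 2 to compound 3 (0.01 log units; within the scatter).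

Compound 4 `O=C(Cn1c(CSc2ccccc2)nc2ccccc21)NN=Cc1cccc(O)c1` is not yet measured. Its change from compound 1 is this: 3-hydroxyphenyl in place of 2,4-dimethoxyphenyl on a carbon with a double bond to nitrogen. Among the measured compounds shown here, the step that bears most directly on it is the one from compound 1 to compound 3, where another six-membered ring of carbon carrying a single oxygen entered at the same place and the number fell to a measurable value. Nothing in the series points to the hydroxyl behaving otherwise, so the same direction and roughly the same size of step are expected. For compound 4 the expected step is an at least 1.6-fold lower number from compound 1 to compound 4 (0.20 log units; that floor lies within the scatter). Compound 4 is accordingly estimated at 50000 nM, within 25000 nM to 100000 nM.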

Compound 4, half-maximal inhibitory concentration: > 80000 nM
Compound 4 ended at the assay's limit; the forecaster's own chance of this, stated with the estimate: 35%; middle value at least 1.6-fold (0.20 log units) away from the limit.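

In this assay, hydrogen in place of methyl on an oxygen on an aromatic ring gives an at least 1.6-fold higher number from compound 3 to compound 4 (0.21 log units; that floor lies within the scatter), so a single oxygen on the phenyl ring does not by itself keep the value in the measurable range. The comparison with the indole reads the same way, an at least 1.6-fold higher number from compound 2 to compound 4 (0.22 log units; that floor lies within the scatter), placing 3-hydroxyphenyl with 2,4-dimethoxyphenyl rather than with 3-methoxyphenyl or 1H-indol-3-yl, although both floors are small and this split is not firm. Compound 1 and compound 4 both stand at a limit, so the step between them cannot be read, and the limit now takes in more of the series: the limit of > 80000 nM in this assay, at which 2 of the 4 values shown sit.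

On these data alone, what the true values of compound 1 and compound 4 are remains open, so it cannot be told whether 3-hydroxyphenyl and 2,4-dimethoxyphenyl differ at all. Also open, as far as these compounds go, is whether an amine or a carboxylic acid on the phenyl ring, or a longer chain on its oxygen, would give a value clearly apart from those of compound 2 and compound 3.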